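Fluoro for Ethyl on a Fused Ring: Expected Cell Effect

The compounds below may be only part of what the source reports. "The series", "measured", "known", "first", "only" and "open" are said of these compounds alone.

Of the compounds shown here, three have been tested in a functional assay on Hep 3B2 cells (Homo sapiens) for antiproliferative activity, read by MTT assay, with a stated time of 24 h, tested at 0.01 ug/mL; a lower number here means a weaker effect, a higher number a stronger effect of the compound at the concentration tested. Compound 1 `Cc1c(C(=O)Nc2c(F)cc(-c3cccc(F)c3)cc2F)nc2ccc(F)cc2c1O` gives -0.12%, compound 2 `Cc1ccc2nc(C(=O)Nc3c(F)cc(-c4cccc(F)c4)cc3F)c(C)c(C(=O)O)c2c1` gives 0.36%, and compound 3 `CCc1ccc2nc(C(=O)Nc3c(F)cc(-c4cccc(F)c4)cc3F)c(C)c(C(=O)O)c2c1` gives -0.25%. Compound 3 has the lowest of the three numbers, but its nearest neighbour is compound 1 and its furthest is compound 2, and both gaps lie within the scatter, so the three compounds cannot be told apart on these figures. Within the data shown here, the one measured step, a number 0.6 percentage points lower from compound 2 to compound 3 (within the scatter), is methyl in place of hydrogen on a saturated chain carbon bound to an aromatic carbon, and it also stays within the scatter.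

Compound 4 `Cc1c(C(=O)Nc2c(F)cc(-c3cccc(F)c3)cc2F)nc2ccc(F)cc2c1C(=O)O` is not yet measured. It differs from compound 3 by fluoro in place of ethyl on an aromatic carbon. Among the measured compounds shown here, no measured step involves this same change, so the only guide is that every change seen so far has left the read-out essentially unmoved at this concentration. Compound 4 is therefore expected to show no step beyond the scatter, a number 0.3 percentage points higher from compound 3 to compound 4 (within the scatter). The estimate for compound 4 is 0%, within a range from -6% to 6%.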

Compound 4, a percentage reported as inhibition, at one concentration (the size of the read-out at that concentration, not a potency): -0.35%
Estimate against measurement, compound 4: 0.4 percentage points above; measured number inside the range.
By their numbers in this assay, from the lowest: compounds 4, 3, 1 and 2 (each within the scatter of the next).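

In this assay, fluoro in place of ethyl on this aromatic carbon gives a number 0.1 percentage points lower from compound 3 to compound 4 (within the scatter) and fluoro in place of methyl at the same place gives a number 0.7 percentage points lower from compound 2 to compound 4 (within the scatter) and thus a halogen now joins the two small carbon groups there without separating the compounds. The other single change, carboxy in place of hydroxy on an aromatic carbon, gives a number 0.2 percentage points lower from compound 1 to compound 4 (within the scatter) and so does not separate that pair either. Nothing available explains why these read-outs stay together.

Every figure sits close to zero at this one concentration, so the compounds shown cannot tell whether this position matters for the effect on these cells at all. Going by these compounds, whether an amine or a longer chain such as butyl at this place would give a read-out beyond the scatter stays open.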